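The source may report more compounds than this note shows. Statements on the series, on what has been measured and on what is new or still open speak of the compounds shown alone.

Measured so far:
compound 1 `Cc1cc(=O)n([C@@H]2O[C@H](COP(=O)(O)OP(=O)(O)O)[C@@H](O)[C@H]2O)c(=O)[nH]1`: > 1000 nM
compound 2 `CCCc1cc(=O)n([C@@H]2O[C@H](COP(=O)(O)OP(=O)(O)O)[C@@H](O)[C@H]2O)c(=O)[nH]1`: > 1000 nM
compound 3 `Cn1c(=O)ccn([C@@H]2O[C@H](COP(=O)(O)O)[C@@H](O)[C@H]2O)c1=O`: >= 100000 nM

All three were tested in an in vitro functional assay on 1321-N1 cells for agonist activity at P2Y purinoceptor 6 (Homo sapiens); on this read-out higher numbers stand for an effect only at larger amounts of compound and lower numbers for an effect already at smaller amounts. In this assay compound 1 reaches only a limit, > 1000 nM. In this assay compound 2 likewise reaches only a limit, > 1000 nM. The step that the two limits leave unreadable from compound 1 to compound 2, an ethyl in place of hydrogen on a saturated chain carbon bound to an aromatic carbon, therefore cannot be read, because both values sit at the limit of > 1000 nM in this assay, at which 2 of the 3 values shown sit. Compound 2 thus stands at a limit, with no number of its own.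

Compound 4 `CCCc1cc(=O)n([C@@H]2O[C@H](COP(=O)(O)O)[C@@H](O)[C@H]2O)c(=O)[nH]1` differs from compound 2 by a hydrogen atom in place of a group of 4 heavy atoms (3 oxygen, 1 phosphorus; no ring), on an oxygen. Among the compounds with values here, no measured step covers this change directly. The nearest point of comparison is compound 3, which carries the same shortened phosphate end as compound 4 on a different core. In this assay compound 3 reaches only a limit, >= 100000 nM, and this is the line (the limit of >= 100000 nM in this assay, at which 1 of the 3 values shown sits). On that basis compound 4 is expected to fall at about 100000 nM, most likely again reported as a limit, within a range from 10000 nM to 1000000 nM. The step that the limit leaves unreadable from compound 2 to compound 4 is thus expected to run toward weaker activity.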

Compound 4, half-maximal effective concentration: > 100000 nM
Compound 4: only a limit was reported (the forecaster's own chance of this, stated with the estimate: 85%); the middle value sits exactly at the limit.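

Compound 2 and compound 4 each stand only at a limit in this assay, so the step between them, a hydrogen atom in place of a group of 4 heavy atoms on an oxygen, cannot be read. The compounds shown leave open what actual value any of them has in this assay, and so how large this step is.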